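The source may report more compounds than this note shows. Statements on the series, on what has been measured and on what is new or still open speak of the compounds shown alone.

Among the measured compounds shown here, compound 2 `Cc1ccc(CO/N=C2/C(c3c[nH]c4ccccc34)=Nc3ccccc32)cc1` is one of two compounds so far measured in a functional assay on SK-OV-3 cells (Homo sapiens) for cytotoxicity, read by MTT assay, with a stated time of 2 days (a lower number here means a stronger inhibitor, a higher number a weaker inhibitor), and in that test compound 2 gives 32400 nM. That is the higher of the two numbers: compound 1 `Fc1ccc2c(c1)/C(=N\OCc1ccccc1)C(c1c[nH]c3ccc(F)cc13)=N2` gives 12300 nM in this assay, a gap beyond the usual scatter, so compound 1 is the stronger inhibitor of the pair. Compound 3 `FC(F)(F)c1ccc(CO/N=C2/C(c3c[nH]c4ccccc34)=Nc3ccccc32)cc1` has not yet been measured. It differs from compound 2 in one place: trifluoromethyl in place of methyl on an aromatic carbon, on an aromatic carbon of a six-membered aromatic ring of carbon only, para to a large group. For the measured compounds named here, no measured pair shows what such a swap does in this assay, so nothing on record sets its size. The expected step is a 1.3-fold lower number from compound 2 to compound 3 (0.11 log units; within the scatter), which would stay within the scatter, with no clear direction. Compound 3 is therefore estimated at 25000 nM in this assay, with a range from 8000 nM to 80000 nM.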

Compound 3, half-maximal inhibitory concentration: 24200 nM
Compound 3: middle estimate off by 1.0-fold (0.01 log units), on the high side; measured number inside the range.
By their numbers in this assay, from the lowest: compounds 1, 3 and 2 (each within the scatter of the next, the first and the last beyond it).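

In this assay, among the compounds shown here, trifluoromethyl in place of methyl on this aromatic carbon, para to a large group, gives a 1.3-fold lower number from compound 2 to compound 3 (0.13 log units; within the scatter), the first measured step at this position. Compound 2 and compound 3 therefore cannot be told apart in this test, even though four heavy atoms stand where one stood before, so this position tolerates that larger group here without a change beyond the scatter. Nothing measured alongside these compounds offers an explanation for this result.

The compounds shown leave open whether an amine, a carboxylic acid or a methoxy group on the same carbon would also read like methyl. Also open, on these data alone, is whether the same swap would give a similar step on a core carrying fluorine, such as that of compound 1.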